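Lengthening the Ester Chain from Compound 2 to Compound 3

A few compounds are considered here, and "the series" means these few. Any claim that something is new, unique, unknown or untested is made for them only; others in the source may bear on it.

In an ADME assay on Vero cells (Chlorocebus sabaeus) for cytotoxicity, read by MTT assay (on this read-out higher numbers stand for weaker inhibition and lower numbers for stronger inhibition), two compounds with a shared core have been measured so far. Compound 1 (`CCCCCCCCCCC(=O)OCC(C)(C)CC1=C(O)C(=O)c2ccccc2C1=O`) reads > 233000 nM, which is a limit of the assay and not a number. Among the measured compounds shown here, compound 2 (`CCCCCCCCCCCC(=O)OCC(C)(C)CC1=C(O)C(=O)c2ccccc2C1=O`) gives 249000 nM, the only true number available. For the measured compounds named here, the single measured step, a step that the limit leaves unreadable from compound 1 to compound 2, places a methyl in position of a hydrogen on the chain, and its size cannot be read against (the limit of > 233000 nM in this assay, at which 1 of the 2 values shown sits).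

Compound 3 (`CCCCCCCCCCCCCCCC(=O)OCC(C)(C)CC1=C(O)C(=O)c2ccccc2C1=O`) follows from compound 2 by a larger change of the same kind: butyl in place of hydrogen on a saturated chain carbon, ten or more bonds along the chain from a carbonyl carbon. Going by the values given here, the chain thus grows again at its far end, and the only related step, a step that the limit leaves unreadable from compound 1 to compound 2, offers no size and no direction to carry over. With compound 2 at 249000 nM as the sole anchor, no shift beyond the usual scatter is expected. For compound 3, a limit rather than a number is a real possibility. The expected step of a 1.1-fold lower number from compound 2 to compound 3 (0.04 log units; within the scatter) therefore stays within that scatter. For compound 3 the estimated value is 225000 nM, with an expected range of 110000 nM to 450000 nM.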

Compound 3, half-maximal inhibitory concentration: 4410 nM
Compound 3: middle estimate off by 51-fold (1.71 log units), on the high side, outside the stated range (below it).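

In this assay, butyl in place of hydrogen on a saturated chain carbon, ten or more bonds along the chain from a carbonyl carbon, gives the first readable size for a change at this position, a 56-fold lower number from compound 2 to compound 3 (1.75 log units; beyond the scatter), so that the chain can no longer be treated as a part that leaves the read-out alone. Pentyl in place of hydrogen at the same place points the same way, with an at least 52-fold lower number from compound 1 to compound 3 (1.72 log units; beyond the scatter), while the earlier step between the two shorter esters still cannot be read. The value of compound 1 is a limit and not a number, so the second step gives only a minimum size and the first is the one exact measure of the change: the limit of > 233000 nM in this assay, at which 1 of the 3 values shown sits.

The compounds shown leave open whether a longer chain would lower the number further or whether the fall stops, and how the number runs over chain lengths short of the one in compound 3. They also leave open whether an amine or a carboxylic acid placed on the chain would keep the lower number seen for compound 3.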